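Replacing methyl on the amide nitrogen with a pyridinyl group

This account rests on a few compounds, and the source may have more. Where it says the series, first, only, none or still open, it means among the compounds named here.

Measured so far:
compound 1, `CCOC(=O)c1c(O)c2cccnc2n(-c2ccccc2)c1=O`, gives 23.5% in a functional assay on the whole organism for inhibition, with Rattus norvegicus as the target, read by paw edema, at a dose of 100 mg/kg by the oral route; on this read-out lower numbers stand for less inhibition and higher numbers for more inhibition at the one dose given (going by the name of the read-out).
compound 2, `CNC(=O)c1c(O)c2cccnc2n(-c2ccccc2)c1=O`, gives 9.6% in this assay.

Among the compounds with values here, compound 2 stands at the lowest of the two numbers measured in this assay; the only step known is a number 13.9 percentage points lower from compound 1 to compound 2 (beyond the scatter).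

Compound 3, `Cc1cnccc1NC(=O)c1c(O)c2cccnc2n(-c2ccccc2)c1=O`, differs from compound 2 at one place: 3-methylpyridin-4-yl in place of methyl on an amide-type nitrogen. Within the data shown here, no measured step touches this place, since the one step known concerns the carbonyl carbon and not the amide-type nitrogen, so nothing measured here speaks to its size or direction. The expectation therefore rests on the two measured numbers alone and stays wide. For compound 3 a value of about 18% is expected in this assay, between 3% and 38%. This estimate means a step of a number 8.4 percentage points higher from compound 2 to compound 3 (within the scatter), which is expected to stay within or only just beyond the usual scatter.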

Compound 3, a percentage reported as inhibition, in the whole organism at one dose (the size of the read-out at that dose, not a potency): 26.9%
For compound 3 the middle estimate is 8.9 percentage points below the measured one; measured number inside the range.
By their numbers in this assay, from the lowest: compound 2; then compounds 1 and 3 (each within the scatter of the next).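

In this assay, within the data shown here, the amide-type nitrogen turns out to be a place where the group matters: 3-methylpyridin-4-yl in place of methyl gives a number 17.3 percentage points higher from compound 2 to compound 3 (beyond the scatter) and is the first change measured at this nitrogen. The second step, a number 3.4 percentage points higher from compound 1 to compound 3 (within the scatter) for (3-methylpyridin-4-yl)amino in place of ethoxy on the carbonyl carbon, shows that these two groups cannot be told apart here, so an amide at this carbonyl carbon need not go with the low number of compound 2. Nothing available explains why the larger group gives the higher number.

As far as these compounds go, whether the step goes with the ring or with its methyl group stays open, and a plain pyridin-4-yl or phenyl on this nitrogen would separate the two. From the compounds shown here alone, how a longer chain such as butyl or a ring with an amine such as piperidine would read at this nitrogen also remains unknown.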